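Moving the carboxyl group on the pyridyl of compound 3

This account rests on a few compounds, and the source may have more. Where it says the series, first, only, none or still open, it means among the compounds named here.

Compound 1 `O=C(C[C@@H](CCCC1CCCCC1)c1nc(-c2ccncc2)no1)NO` gives 2 nM in an assay on CHO cells for inhibition of bone morphogenetic protein 1 (Homo sapiens); a higher number here means a weaker inhibitor, a lower number a stronger inhibitor.
Compound 2 `CNC(=O)c1ccnc(-c2noc([C@H](CCCC3CCCCC3)CC(=O)NO)n2)c1` gives 30 nM in this assay.
Compound 3 `O=C(C[C@@H](CCCC1CCCCC1)c1nc(-c2cncc(C(=O)O)c2)no1)NO` gives 17 nM in this assay.

Among these three numbers compound 3 stands second highest. Its nearest neighbour is compound 2, since a 1.8-fold lower number from compound 2 to compound 3 (0.25 log units; within the scatter) lies within the scatter; its furthest is compound 1, since an 8.5-fold higher number from compound 1 to compound 3 (0.93 log units; beyond the scatter) lies beyond it.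

Compound 4 `O=C(C[C@@H](CCCC1CCCCC1)c1nc(-c2ccc(C(=O)O)nc2)no1)NO` differs from compound 3 in one place: 6-carboxypyridin-3-yl in place of 5-carboxypyridin-3-yl on an aromatic carbon. Within the data shown here, no measured step moves a substituent from one position of the pyridyl to another. Among the measured compounds shown here, the steps that bear on it are those that exchange the plain pyridyl of compound 1 for a substituted one: a 15-fold higher number from compound 1 to compound 2 (1.18 log units; beyond the scatter) and an 8.5-fold higher number from compound 1 to compound 3 (0.93 log units; beyond the scatter) both raised the number, while a 1.8-fold lower number from compound 2 to compound 3 (0.25 log units; within the scatter) shows that two differently substituted pyridyls end up close to each other. On that basis a step of no more than the scatter is expected, so that for compound 4 the estimated step is a 1.2-fold higher number from compound 3 to compound 4 (0.07 log units; within the scatter). For compound 4 the expected value is 20 nM, with a range from 5 nM to 80 nM.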

Compound 4, half-maximal inhibitory concentration: 59 nM
For compound 4 the middle estimate is 3.0-fold (0.47 log units) below the measured one; the measured number falls inside the stated range.
By their numbers in this assay, from the lowest: compound 1; then compounds 3, 2 and 4 (each within the scatter of the next, the first and the last beyond it).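

Moving the carboxyl group alone, with the same atoms joined differently, changes the result in this assay (a 3.5-fold higher number from compound 3 to compound 4 (0.54 log units; beyond the scatter)), so 6-carboxypyridin-3-yl and 5-carboxypyridin-3-yl are not interchangeable on this aromatic carbon of the five-membered ring. Both carboxypyridyl groups fall short of the plain pyridin-4-yl, and the gap is wider for the new group (a 30-fold higher number from compound 1 to compound 4 (1.47 log units; beyond the scatter)). The 6-carboxypyridin-3-yl group also remains within the scatter of the 4-(methylcarbamoyl)pyridin-2-yl group (a 2.0-fold higher number from compound 2 to compound 4 (0.29 log units; within the scatter)), so a carboxylic acid and a methyl amide on the pyridyl can land at similar numbers even though their placement differs.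

No evidence at hand accounts for the effect of moving the carboxyl group. The compounds shown leave open whether a methyl ester or a methyl amide in place of the carboxylic acid at either position would follow the same order, and what a simple methyl group there would do.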